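This account rests on a few compounds, and the source may have more. Where it says the series, first, only, none or still open, it means among the compounds named here.

In an ADME assay on HEK293 cells (Homo sapiens) for cytotoxicity, with a stated time of 72 h (a higher number here means that more compound is needed for the effect, a lower number that less compound is needed), the compounds are compared by the concentration at which half of the cells are affected. Compound 1 `Cc1cc(NC(=O)Nc2ccc([N+](=O)[O-])c(C(F)(F)F)c2)c2ccccc2n1` gives > 25000 nM, which is a limit of the assay and not a number. Compound 2 `Cc1cc(NC(=O)Nc2cc(F)ccc2F)c2ccccc2n1` gives 12000 nM. Compound 3 `Cc1ccc(NC(=O)Nc2cc(C)nc3ccccc23)cc1` gives > 25000 nM, again a limit rather than a measured number. Compound 3 therefore stands at the limit of > 25000 nM in this assay, at which 2 of the 3 values shown sit, and since only a limit is known for it, its position relative to compound 2 cannot be fixed more closely than that.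

Compound 4 `Cc1cc(NC(=O)Nc2ccc(O)cc2)c2ccccc2n1` has not yet been measured. It differs from compound 3 in one place: hydroxy in place of methyl on an aromatic carbon. Within the data shown here, no pair of measured compounds differs by a change of this kind, so the size of the step cannot be read from the values shown. The step is expected to be none beyond the usual scatter, so that a number no higher from compound 3 to compound 4 (the limit leaves the size open) is estimated. Compound 4 is expected to give about 25000 nM, with a range from 10000 nM to 60000 nM, and it would not be surprising if the assay again reported only a limit for compound 4.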

Compound 4, half-maximal effective concentration: > 25000 nM
Compound 4: a limit, no number; the forecaster's own chance of this, stated with the estimate: 65%; the middle value lies on the limit itself.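

Compound 3 and compound 4 both end at a limit of the assay rather than a number, so no size can be read for the step between them: the limit of > 25000 nM in this assay, at which 3 of the 4 values shown sit. The compounds shown leave open whether hydroxy in place of methyl on an aromatic carbon changes the concentration needed in this assay at all.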